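Trifluoromethyl on a Series Sitting at a Limit

The source may hold more compounds than are shown below. What is called first, only, known or untested is meant among the compounds shown, and "the series" means these compounds.

Compound 1 `O=C(NCc1ccccc1Br)N1C(=O)c2ccccc2S1(=O)=O`: > 166 h (a limit)
Compound 2 `O=C(NCc1ccccc1F)N1C(=O)c2ccccc2S1(=O)=O`: > 166 h (a limit)
Compound 3 `O=C(NCc1ccccc1)N1C(=O)c2ccccc2S1(=O)=O`: > 166 h (a limit)

In a physicochemical assay for pharmacokinetics (on this read-out lower numbers stand for a shorter-lived compound and higher numbers for a longer-lived compound), compound 3 stands at > 166 h as a limit and not as a number. Its two companions offer no number either, so its true place among them cannot be read. Compound 4 `O=C(NCc1ccccc1C(F)(F)F)N1C(=O)c2ccccc2S1(=O)=O` differs from compound 3 by trifluoromethyl in place of hydrogen on an aromatic carbon and so carries trifluoromethyl in place of hydrogen on an aromatic carbon.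

Three measured changes on an aromatic carbon bear on this: a step that the two limits leave unreadable from compound 1 to compound 3 and a step that the two limits leave unreadable from compound 2 to compound 3 and also a step that the two limits leave unreadable from compound 1 to compound 2 as the third. None of them gives a size to carry over because of the limit of > 166 h in this assay, at which 3 of the 3 values shown sit, and none gives a direction. No step beyond the usual scatter is therefore expected in this assay and the data favour no direction. The step expected by this estimate is a step that the limit leaves unreadable from compound 3 to compound 4 and it rests on compound 3 with its limit of > 166 h as the only anchor. Compound 4 is expected near 200 h with an estimated range from 120 h to 500 h and will most likely be reported as a limit again.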

Compound 4, half-life: > 166 h
Compound 4: only a limit was reported; the forecaster's own chance of this, stated with the estimate: 85%; the middle value lies beyond the limit too.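

Compound 4 is reported only as a limit, so its steps from compound 1, compound 2 and compound 3 cannot be read in this assay: the limit of > 166 h in this assay, at which 4 of the 4 values shown sit.

The compounds shown leave open how the four compare in this assay, and whether any of these changes on the aromatic carbon shifts the read-out at all.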